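A few compounds are considered here, and "the series" means these few. Any claim that something is new, unique, unknown or untested is made for them only; others in the source may bear on it.

In a functional assay on LNCaP cells (Homo sapiens) for antiproliferative activity, read by WST assay, with a stated time of 3 days (on this read-out lower numbers stand for stronger inhibition and higher numbers for weaker inhibition), compound 1 `COc1cc(-c2oc3ccccc3c(=O)c2OC(C)C)cc(OC)c1OC` gives 8800 nM and compound 2 `CCC(C)Oc1c(-c2cc(OC)c(OC)c(OC)c2)oc2ccccc2c1=O` gives 9300 nM. Going by the values given here, these two values lie within the scatter of each other, so compound 2 stands level with the only other measured compound. Compound 3 `CCN(CC)CCCCOc1c(-c2cc(OC)c(OC)c(OC)c2)oc2ccccc2c1=O` differs from compound 2 by having 4-(diethylamino)butyl in place of sec-butyl on an oxygen on an aromatic ring. Among the compounds with values here, one measured step bears on this change, and only loosely: a 1.1-fold higher number from compound 1 to compound 2 (0.02 log units; within the scatter), for methyl in place of hydrogen on a saturated chain carbon. That step shows that a small alteration to the alkyl group left this assay flat, but it is a far smaller edit than the one now at issue. Within the data shown here, no measured compound carries a diethylamino group, so the data give no direct size for this exchange. A moderate move toward stronger inhibition is expected, with a wide range that still includes no real change. The expected change is a 2.3-fold lower number from compound 2 to compound 3 (0.37 log units; beyond the scatter). For compound 3 the estimated value is 4000 nM, with an expected range of 1300 nM to 12000 nM.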

Compound 3, half-maximal inhibitory concentration: 13500 nM
The estimate for compound 3 lay 3.4-fold (0.53 log units) below the measured number, outside the stated range (above it).
By their numbers in this assay, from the lowest: compounds 1, 2 and 3 (each within the scatter of the next).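

In this assay, placing 4-(diethylamino)butyl on the oxygen on an aromatic ring in place of sec-butyl gives a 1.5-fold higher number from compound 2 to compound 3 (0.16 log units; within the scatter) and in place of isopropyl gives a 1.5-fold higher number from compound 1 to compound 3 (0.19 log units; within the scatter) as the second reading, so neither exchange separates compound 3 from the compounds with the shorter alkyl groups. The earlier pair showed only that adding a single methyl to the alkyl group left the number level, whereas this result extends that flat picture to a much larger chain ending in a diethylamino group, with all three compounds within the scatter of one another. Nothing on hand accounts for this level read-out across the three groups.

The compounds shown leave open whether this position stays as flat with a carboxylic acid at the end of the chain, a piperidine in place of the diethylamino group, or a shorter chain carrying the same amine. They also leave open whether a plain hydrogen on that oxygen would give a number distinct from those of compound 1, compound 2 and compound 3.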